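From 4-butoxyphenyl to 2-fluorophenyl on a carbonyl carbon

This account rests on a few compounds, and the source may have more. Where it says the series, first, only, none or still open, it means among the compounds named here.

Measured in a functional assay on OVCAR-3 cells (Homo sapiens) for antiproliferative activity, read by MTT assay, with a stated time of 24 h; on this read-out higher numbers stand for weaker inhibition and lower numbers for stronger inhibition:
- Compound 1 `Cc1ccccc1NNC(=O)c1cccc(NS(=O)(=O)c2cnc(O)nc2O)c1`: > 20000 nM (a limit of the assay)
- Compound 2 `CCCCOc1ccc(C(=O)NNC(=O)c2cccc(NS(=O)(=O)c3cnc(O)nc3O)c2)cc1`: 9200 nM

The entry for compound 1 is a limit, not a number. Among the compounds with values here, compound 2, at 9200 nM, holds the only actual number so far. Compound 3 `O=C(NNC(=O)c1ccccc1F)c1cccc(NS(=O)(=O)c2cnc(O)nc2O)c1` has 2-fluorophenyl in place of 4-butoxyphenyl on a carbonyl carbon. Within the data shown here, no measured step shows the effect of such a change. In this assay, a modest move towards weaker inhibition is expected, with an estimated 2.0-fold higher number from compound 2 to compound 3 (0.29 log units; within the scatter). Compound 3 is expected at 18000 nM, within an estimated range of 7000 nM to 40000 nM.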

Compound 3, half-maximal inhibitory concentration: 10800 nM
Compound 3: the middle estimate sits 1.7-fold (0.22 log units) above what was measured, within the range that was stated.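

The exchange of one phenyl group for the other on a carbonyl carbon gives a 1.2-fold higher number from compound 2 to compound 3 (0.07 log units; within the scatter) in this assay, so the two groups cannot be told apart at this position, despite the difference in heavy atoms. The change of (2-fluorophenyl)carbonyl for 2-methylphenyl on an amine nitrogen gives an at least 1.8-fold lower number from compound 1 to compound 3 (0.26 log units; that floor lies within the scatter), which sets no firm order. The entry for compound 1 is a limit, not a number: the limit of > 20000 nM in this assay, at which 1 of the 3 values shown sits.

From the compounds shown here alone, whether an amine, a carboxylic acid or a longer chain on this carbonyl carbon would move the number beyond the scatter remains open.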